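A few compounds are considered here, and "the series" means these few. Any claim that something is new, unique, unknown or untested is made for them only; others in the source may bear on it.

Compounds measured in an ADME assay on HEK293 cells (Homo sapiens) for cytotoxicity, read by MTT assay, with a stated time of 72 h; on this read-out lower numbers stand for stronger inhibition and higher numbers for weaker inhibition: compound 1 `COc1cc(C2=C(c3cc(C)c(OC)c(C)c3)C(O)CC2=O)cc(OC)c1OC`, compound 2 `COc1cc(C2=C(c3cc(C)c(OC)c(C)c3)C(OC(C)=O)CC2=O)cc(OC)c1OC` and compound 3 `CC(=O)OC1C/C(=N/O)C(c2ccccc2)=C1c1ccccc1`. Compound 4 `O/N=C1/CC(O)C(c2ccccc2)=C1c1ccccc1` has not yet been measured in this assay.

In this assay compound 1 reaches only the limit > 100 ug/mL, a limit of the method and not a number. Compound 2 likewise gives only the limit > 100 ug/mL. Both therefore sit at the limit of > 100 ug/mL in this assay, at which 2 of the 3 values shown sit. For the measured compounds named here, compound 3 gives 92.3 ug/mL, the only actual number among the three.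

The change from compound 2 to compound 1, (hydrogen in place of acetyl on an oxygen on a saturated carbon), yields a step that the two limits leave unreadable from compound 2 to compound 1. Compound 3 and compound 2 share no single counted change; the difference between the two cores is not broken down here.

The same change is made from compound 3 to compound 4, (hydrogen in place of acetyl on an oxygen on a saturated carbon), with the place described in the same words. The expected step is a 1.0-fold higher number from compound 3 to compound 4 (0.01 log units; within the scatter), since a step that the two limits leave unreadable from compound 2 to compound 1 offers no readable size and compound 3 already stands close to the limit of > 100 ug/mL in this assay, at which 2 of the 3 values shown sit. Compound 4 is expected at 95 ug/mL, between 40 ug/mL and 200 ug/mL, with a real chance that only a limit is returned.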

Compound 4, half-maximal inhibitory concentration: > 100 ug/mL
Compound 4: no number, only a limit; the forecaster's own chance of this, stated with the estimate: 50%; middle value at least 1.0-fold (0.02 log units) from the limit.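

In this assay, replacing acetoxy with hydroxy on the core of compound 3 gives an at least 1.0-fold higher number from compound 3 to compound 4 (0.03 log units; that floor lies within the scatter). Compound 4 returns only a limit, > 100 ug/mL, and not a number. Compound 1 and compound 4, the two hydroxy compounds, therefore both end at a limit, which is all that carries across the two cores; whether the change has the same size on both cores remains unshown, since the step on the core of compound 2 cannot be read, the step on the core of compound 3 is only a floor, and most values rest at one boundary: the limit of > 100 ug/mL in this assay, at which 3 of the 4 values shown sit.

Open, on these data alone, is how other groups on this oxygen on a saturated carbon would read in this assay, for example an aminoacetyl group or a longer acyl chain, or an amine or a carboxylic acid in place of the acetoxy. With compound 3 at 92.3 ug/mL as the only actual number, the compounds shown give no size for any change at this place.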